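From trifluoromethyl to trifluoromethoxy in compound 1

The compounds below may be only part of what the source reports. "The series", "measured", "known", "first", "only" and "open" are said of these compounds alone.

Compound 1 `CC(=O)N[C@@H]1CCN(c2cc(C)nn3c(-c4ccc(C(F)(F)F)cc4)c(C)nc23)C1`: > 95%
Compound 2 `COc1ccc(-c2c(C)nc3c(N4CC[C@@H](NC(C)=O)C4)cc(C)nn23)cc1F`: > 95%
Compound 3 `CC(=O)N[C@@H]1CCN(c2cc(C)nn3c(-c4nccs4)c(C)nc23)C1`: > 95%

In an ADME assay on microsomes from liver (Homo sapiens) for metabolic stability, read by LC-MS, with NADPH named in the record, with a stated time of 60 min, tested at 1 uM, in the absence of a further agent (a lower number here means that less of the compound is left, a higher number that more of the compound is left), compound 1 gives > 95%, which is a limit of the assay and not a number. It has company there, for the record so far is the limit of > 95% in this assay, at which 3 of the 3 values shown sit. So compound 1 cannot be ranked against compound 2 or compound 3, and all that can be said is that the three share the same limit.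

The next compound to be tested is compound 4 `CC(=O)N[C@@H]1CCN(c2cc(C)nn3c(-c4ccc(OC(F)(F)F)cc4)c(C)nc23)C1`. It differs from compound 1 in a single group: trifluoromethoxy in place of trifluoromethyl on an aromatic carbon. Put simply, trifluoromethoxy stands in place of trifluoromethyl on an aromatic carbon of a six-membered aromatic ring of carbon only.

Within the data shown here, no measured step makes this exact change, but two measured steps replace the whole ring that carries the group. One is a step that the two limits leave unreadable from compound 1 to compound 2, and the other is a step that the two limits leave unreadable from compound 1 to compound 3. Neither has a size that can be read, so they offer only weak guidance. Resting on a step that the two limits leave unreadable from compound 1 to compound 2 and on a step that the two limits leave unreadable from compound 1 to compound 3, no step beyond the usual scatter is expected in this assay, in either direction.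

The expected change is a step that the limit leaves unreadable from compound 1 to compound 4. For compound 4 the estimate is 96%, with an expected range from 85% to 100%.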

Compound 4, percent of the compound remaining: > 95%
Compound 4 was reported as a limit (the forecaster's own chance of this, stated with the estimate: 65%); the middle value does not contradict the limit.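

In this assay compound 4 gives > 95%, which is a limit of the assay and not a number. The step between compound 1 and compound 4 therefore cannot be read, so the swap of trifluoromethyl for trifluoromethoxy has no size that can be stated. The compounds shown leave open whether they differ at all in how much of each remains, and how they would rank: the limit of > 95% in this assay, at which 4 of the 4 values shown sit.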